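Chalcone Analogues Tested for Cytotoxicity on HeLa Cells

The compounds below may be only part of what the source reports. "The series", "measured", "known", "first", "only" and "open" are said of these compounds alone.

The series covers three measured chalcones. Compound 1 `COc1cc(O)c(C(=O)/C=C/c2ccc(O)cc2)c(OC)c1CC=C(C)C` gives 25600 nM in a functional assay on HeLa cells (Homo sapiens) for cytotoxicity, read by MTT assay; on this read-out higher numbers stand for weaker inhibition and lower numbers for stronger inhibition. Compound 3 `COc1cc(OC)c(C(=O)/C=C/c2ccc(O)cc2)c(O)c1CC=C(C)C` gives 11800 nM in this assay. Compound 2 `COc1cc(O)c(CC=C(C)C)c(O)c1C(=O)/C=C/c1ccccc1O` gives 5900 nM in this assay, the lowest number of the three; its gap to compound 3 lies within the scatter, while its gap to compound 1 lies beyond it.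

The step of interest leads from compound 2 to compound 4 `COc1cc(O)c(CC=C(C)C)c(O)c1C(=O)/C=C/c1cc(O)cc(O)c1`, which has not yet been measured in this assay. The change is confined to the aryl group on the enone: 3,5-dihydroxyphenyl in place of 2-hydroxyphenyl on a double-bonded chain carbon bound to a double-bonded chain carbon. Among the compounds with values here, no measured pair in the set shares this change, so there is no direct precedent for its size or direction.

Given that the measured values of compound 1, compound 2 and compound 3 differ only modestly, compound 4 is expected to land close to compound 2, with a step of a 1.4-fold higher number from compound 2 to compound 4 (0.13 log units; within the scatter) that is not expected to exceed the scatter. The estimate for compound 4 in this assay is 8000 nM, within a range from 3000 nM to 25000 nM.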

Compound 4, half-maximal inhibitory concentration: 3200 nM
Compound 4: middle estimate off by 2.5-fold (0.40 log units), on the high side; low and high end bracket the measured number.
By their numbers in this assay, from the lowest: compounds 4, 2 and 3 (each within the scatter of the next, the first and the last beyond it); then compound 1.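

Within the data shown here, this is the first step read at this position: in this assay, 3,5-dihydroxyphenyl in place of 2-hydroxyphenyl on a double-bonded chain carbon bound to a double-bonded chain carbon gives a 1.8-fold lower number from compound 2 to compound 4 (0.27 log units; within the scatter), so the two compounds cannot be told apart. The position therefore accepts a different hydroxyl arrangement on the aryl group, with 2 hydrogen-bond donors in place of 1, without a step beyond the scatter. No measured evidence on the mechanism accompanies this result.

From the compounds shown here alone, whether an aryl group bearing an amine or a carboxylic acid at this same place would give a step beyond the scatter remains open. So does whether the same exchange would read alike on the core of compound 1 or compound 3 .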